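Ethynyl in place of furan-3-yl on the shared core

The source may report more compounds than this note shows. Statements on the series, on what has been measured and on what is new or still open speak of the compounds shown alone.

Of the compounds shown here, three on a shared core have been measured in a functional assay on HepG2 cells (Homo sapiens) for antiproliferative activity, read by XTT assay, with a stated time of 72 h; a lower number here means a stronger inhibitor, a higher number a weaker inhibitor. In this assay compound 1 `C#Cc1cn([C@@H]2O[C@H](CO)[C@@H](O)[C@H]2O)c2ncnc(OC)c12` gives 12700 nM. In the same test compound 2 `Cc1ncnc2c1c(-c1ccoc1)cn2[C@@H]1O[C@H](CO)[C@@H](O)[C@H]1O` gives 5320 nM. Compound 3 `Cc1nc(N)c2c(-c3ccoc3)cn([C@@H]3O[C@H](CO)[C@@H](O)[C@H]3O)c2n1` gives > 20000 nM, and this is a limit of the assay and not a number.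

Compound 4 `C#Cc1cn([C@@H]2O[C@H](CO)[C@@H](O)[C@H]2O)c2nc(C)nc(N)c12` follows from compound 3 with ethynyl in place of furan-3-yl on an aromatic carbon. Going by the values given here, no measured pair shows this change on its own, so the expectation rests on thin ground. Compound 1 also carries ethynyl and gives 12700 nM, though it differs from compound 4 elsewhere on the core. A modest move toward stronger inhibition in this assay is therefore expected, and compound 4 may yet stay at the limit. The estimated change is an at least 2.2-fold lower number from compound 3 to compound 4 (0.34 log units; beyond the scatter). Compound 4 is estimated at 9000 nM, with an expected range from 1500 nM to 20000 nM.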

Compound 4, half-maximal inhibitory concentration: > 20000 nM
Compound 4 gave a limit, no number; the forecaster's own chance of this, stated with the estimate: 40%; middle value at least 2.2-fold (0.34 log units) from the limit.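

Compound 4 gives > 20000 nM, a limit of the assay and not a number. Compound 3 also gives a limit, so no step between the two can be read: the limit of > 20000 nM in this assay, at which 2 of the 4 values shown sit.

The compounds shown leave open whether ethynyl in place of furan-3-yl on an aromatic carbon changes inhibition on this core at all.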